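Sulfamate Amides: Replacing a Bromobenzyl Arm with Benzyl

The compounds below may be only part of what the source reports. "The series", "measured", "known", "first", "only" and "open" are said of these compounds alone.

Measured compounds:
compound 1 `CCN(Cc1ccc(Br)cc1)c1cccc(C(=O)N2CCc3ccc(OS(N)(=O)=O)cc3C2)c1` — 84.5%
compound 2 `CN(C)CCN(CCN(C)C)c1cccc(C(=O)N2CCc3ccc(OS(N)(=O)=O)cc3C2)c1` — 17.1%
compound 3 `CCN(Cc1cccc(Br)c1)c1cccc(C(=O)N2CCc3ccc(OS(N)(=O)=O)cc3C2)c1` — 24.9%

In an assay on HEK293 cells for inhibition of Steryl-sulfatase (Homo sapiens), tested at 1 uM (on this read-out higher numbers stand for a stronger effect at the one concentration tested and lower numbers for a weaker effect), compound 3 stands second highest of the three numbers. Its nearest neighbour is compound 2, whose value lies within the scatter of that of compound 3, so no order between the two can be claimed; compound 1 lies far above it, beyond the scatter. The unmeasured compound 4 `CCCN(Cc1ccccc1)c1cccc(C(=O)N2CCc3ccc(OS(N)(=O)=O)cc3C2)c1` differs from compound 3 in one place: benzyl(propyl)amino in place of (3-bromobenzyl)(ethyl)amino on an aromatic carbon.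

Among the compounds with values here, two measured steps bear on this. The step of a number 59.6 percentage points lower from compound 1 to compound 3 (beyond the scatter) shows how strongly the bromine position on the benzyl arm matters, while a number 7.8 percentage points higher from compound 2 to compound 3 (within the scatter) lies within the scatter. Within the data shown here, no measured step removes the bromine altogether or lengthens the ethyl to propyl, so the direction is uncertain. For compound 4 a modest rise is estimated, a number 15.1 percentage points higher from compound 3 to compound 4 (beyond the scatter), giving an expected value of 40% with a range from 10% to 75%.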

Compound 4, a percentage reported as inhibition, at one concentration (the size of the read-out at that concentration, not a potency): 67.4%
For compound 4 the middle estimate is 27.4 percentage points below the measured one; low and high end bracket the measured number.
By their numbers in this assay, from the lowest: compounds 2 and 3 (each within the scatter of the next); then compound 4; then compound 1.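

In this assay the benzyl(propyl)amino group gives a strong effect with no bromine on the arm, with a number 42.5 percentage points higher from compound 3 to compound 4 (beyond the scatter) and with a number 50.3 percentage points higher from compound 2 to compound 4 (beyond the scatter) at the same aromatic carbon. The (4-bromobenzyl)(ethyl)amino group still keeps a lead, with a number 17.1 percentage points lower from compound 1 to compound 4 (beyond the scatter) on this read-out. Nothing available here explains these differences. The compounds shown leave open how much of the rise belongs to losing the bromine and how much to the propyl chain. From the compounds shown here alone, how a 4-chlorobenzyl arm or a butyl chain would read also remains open.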